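The compounds below may be only part of what the source reports. "The series", "measured", "known", "first", "only" and "open" are said of these compounds alone.

Working notes on the oleoyl ketone series in an assay on isolated protein for inhibition of Fatty-acid amide hydrolase 1 (Homo sapiens); a higher number here means a weaker inhibitor, a lower number a stronger inhibitor. Compound 2 `CCCCCCCC/C=C\CCCCCCC(=O)c1nc2ncccc2o1` gives 2.3 nM. Compound 3 `CCCCCCCC/C=C\CCCCCCC(=O)c1nc2cccc(C)c2o1` gives 13000 nM, the highest of the two numbers recorded; its nearest neighbour is compound 2, a far lower number, well beyond the scatter. Compound 1 `CCCCCCCC/C=C\CCCCCCC(=O)c1nc2cc(C)ccc2o1` returns only a limit, > 100000 nM, the assay ceiling noted at the limit of > 100000 nM in this assay, at which 1 of the 3 values shown sits. Among the measured compounds shown here, no single-change step between measured compounds exists here, so nothing ties the methyl directly to the numbers.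

Compound 4 `CCCCCCCC/C=C\CCCCCCC(=O)c1nc2ccccc2o1` is still to be measured. It differs from compound 3 by hydrogen in place of methyl on an aromatic carbon. Compound 4 shares the unsubstituted carbocyclic face with compound 2, and in this assay compound 2 gives 2.3 nM. On that basis a large decrease is expected, a 650-fold lower number from compound 3 to compound 4 (2.81 log units; beyond the scatter). Compound 4 is estimated at 20 nM, within 3 nM to 200 nM.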

Compound 4, inhibition constant: 370 nM
Compound 4: the middle estimate sits 19-fold (1.27 log units) below what was measured; measured number outside the range, above it.
By their numbers in this assay, from the lowest: compound 2; then compound 4; then compound 3. At a limit, above all of these: compound 1.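

Hydrogen in place of methyl on this aromatic carbon gives a clear gain in this assay, a 35-fold lower number from compound 3 to compound 4 (1.55 log units; beyond the scatter), so the methyl of compound 3 is a liability here. Hydrogen alone does not reach the number given by the six-membered aromatic ring with 1 hetero atom: a 160-fold higher number from compound 2 to compound 4 (2.21 log units; beyond the scatter). The step of an at least 270-fold lower number from compound 1 to compound 4 (2.43 log units; beyond the scatter) is only a bound, since the value of compound 1 is a limit: the limit of > 100000 nM in this assay, at which 1 of the 4 values shown sits.

Going by these compounds, whether a fluorine, a chlorine or a methoxy group on this carbon would also cost as much as methyl stays open. So does whether a methyl on the ring with the hetero atom would cost as much as it does in compound 3.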